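Exchanging the Carbonyl Partner: From Compound 2 to Compound 3

The source may report more compounds than this note shows. Statements on the series, on what has been measured and on what is new or still open speak of the compounds shown alone.

Compound 1 `COc1cc(Cl)cc(-c2nn(-c3cccc(NC(=O)c4cc(C(F)(F)F)cc(C(F)(F)F)c4)c3)cc2-c2ccncc2)c1` and compound 2 `COc1cc(Cl)cc(-c2nn(-c3cccc(NC(=O)c4ccc(Cl)c(Cl)c4)c3)cc2-c2ccncc2)c1` share one core and differ only in the group attached to the carbonyl. In a functional assay on IGROV-1 cells (Homo sapiens) for inhibition, read by sulforhodamine B assay, with a stated time of 48 h, tested at 10 uM (on this read-out lower numbers stand for a stronger effect and higher numbers for a weaker effect at the one concentration tested), compound 1 gives 100%, while compound 2 gives 71.6%, the lower of the two numbers and set apart from compound 1 by more than the usual scatter. Compound 3 `COc1cc(Cl)cc(-c2nn(-c3cccc(NC(=O)Nc4ccc(Cl)c(Cl)c4)c3)cc2-c2ccncc2)c1` keeps the rest of compound 2 and carries (3,4-dichlorophenyl)amino in place of 3,4-dichlorophenyl on a carbonyl carbon. Among the measured compounds shown here, no measured pair shows this exchange, so its effect has to be judged without a direct precedent. Because compound 2 sits at 71.6%, room exists in both directions, and a step of moderate size is estimated as a number 6.4 percentage points higher from compound 2 to compound 3 (within the scatter), leaning slightly toward a weaker effect. Compound 3 is therefore expected to give about 78%, within a range from 52% to 100%.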

Compound 3, a percentage reported as activity, at one concentration (the size of the read-out at that concentration, not a potency): 36.7%
Estimate against measurement, compound 3: 41.3 percentage points above; the measured number lies below the stated range.
By their numbers in this assay, from the lowest: compound 3; then compound 2; then compound 1.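

In this assay, replacing 3,4-dichlorophenyl with (3,4-dichlorophenyl)amino on a carbonyl carbon gives a number 34.9 percentage points lower from compound 2 to compound 3 (beyond the scatter). The aromatic ring is retained here, while the entering group adds a nitrogen and a hydrogen-bond donor, so the read-out at this position responds to the connection between the ring and the carbonyl, not only to the group on the ring as in the comparison of compound 1 and compound 2. No available measurement explains the stronger effect of this exchange.

The compounds shown leave open whether the gain depends on the amino hydrogen, which an N-methylamino link or an oxygen atom in place of the new nitrogen could separate. They also leave open whether the same exchange would lower the number when the carbonyl partner is that of compound 1.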